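Swapping the Benzamide Aryl Group for a Chloropyridine

This account rests on a few compounds, and the source may have more. Where it says the series, first, only, none or still open, it means among the compounds named here.

Compound 1 `COc1ccc(C(=O)Nc2cccc(-c3oc4cc(-c5ccc(F)cc5)ccc4c(=O)c3O)c2)cc1` gives 6250 nM in a functional assay on MCF7 cells (Homo sapiens) for antiproliferative activity, read by CCK-8 assay, with a stated time of 72 h (on this read-out higher numbers stand for weaker inhibition and lower numbers for stronger inhibition), and stands second highest of the three numbers measured. Compound 3 `O=C(Nc1cccc(-c2oc3cc(-c4ccc(F)cc4)ccc3c(=O)c2O)c1)c1cccc(F)c1` gives 5770 nM, and a 1.1-fold lower number from compound 1 to compound 3 (0.03 log units; within the scatter). Compound 2 `O=C(Nc1cccc(-c2oc3cc(-c4ccc(F)cc4)ccc3c(=O)c2O)c1)c1ccc(F)cc1F` gives 13500 nM, with a 2.2-fold higher number from compound 1 to compound 2 (0.33 log units; beyond the scatter) and a 2.3-fold lower number from compound 2 to compound 3 (0.37 log units; beyond the scatter). The unmeasured compound 4 `O=C(Nc1cccc(-c2oc3cc(-c4ccc(F)cc4)ccc3c(=O)c2O)c1)c1ccc(Cl)nc1` differs from compound 1 in one place: 6-chloropyridin-3-yl in place of 4-methoxyphenyl on a carbonyl carbon. The two measured steps at this carbonyl carbon bear on it; one stayed within the scatter, the other moved modestly toward weaker inhibition. Compound 4 is therefore expected to change little, with the estimated step being a 1.1-fold higher number from compound 1 to compound 4 (0.05 log units; within the scatter). Compound 4 is estimated at 7000 nM, within the range 3000 nM to 16000 nM.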

Compound 4, half-maximal inhibitory concentration: 2890 nM
Compound 4: the middle estimate sits 2.4-fold (0.38 log units) above what was measured, outside the stated range (below it).
By their numbers in this assay, from the lowest: compounds 4, 3 and 1 (each within the scatter of the next, the first and the last beyond it); then compound 2.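

In this assay, going by these compounds alone, the 6-chloropyridin-3-yl group is the first at this carbonyl carbon to take the number beyond the scatter below that of the 4-methoxyphenyl group (a 2.2-fold lower number from compound 1 to compound 4 (0.33 log units; beyond the scatter)), and it also stands well clear of the 2,4-difluorophenyl group (a 4.7-fold lower number from compound 2 to compound 4 (0.67 log units; beyond the scatter)). Against the 3-fluorophenyl group the change stays inside the scatter (a 2.0-fold lower number from compound 3 to compound 4 (0.30 log units; within the scatter)), so a ring with a hetero atom is accepted here without loss. Nothing available accounts for this step. On these data alone, it remains open whether the ring nitrogen or the chlorine carries the step, and whether an amine or a carboxylic acid in place of that chlorine would hold this level.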